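The compounds below may be only part of what the source reports. "The series", "measured", "known", "first", "only" and "open" are said of these compounds alone.

Permeability in an ADME assay on Caco-2 cells (Homo sapiens) for permeability, read by LC-MS, with a stated time of 2 h (a higher number here means that the compound crosses the layer faster, a lower number that the compound crosses the layer more slowly), for the measured members of the series:

compound 1 `CCCN(Cc1ccc(OCCN2C(=O)CCC2=O)c(C)c1)[C@@H](CC(=O)O)c1ccc(Cl)cc1` gives 9.3 nm/s
compound 2 `Cc1cc(CN(CC2CC2)[C@@H](CC(=O)O)c2ccc(Cl)cc2)ccc1OCCN1C(=O)CCC1=O` gives 7.3 nm/s
compound 3 `CCCN(Cc1ccc(OCCn2c(=O)ccn(C)c2=O)c(OC)c1)C(CC(=O)O)c1ccc(Cl)cc1` gives 1 nm/s

Compound 1 and compound 2 share one core and differ in a single place: cyclopropyl in place of ethyl on a saturated chain carbon bound to an amine nitrogen. That change made a 1.3-fold lower number from compound 1 to compound 2 (0.11 log units; within the scatter). Compound 3 carries a different core, and the difference between the two cores is not broken down here; what the numbers show is that compound 3 stands lowest of the three, with compound 2 and compound 1 both well above it in this assay, beyond the usual scatter.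

Compound 4 `COc1cc(CN(CC2CC2)C(CC(=O)O)c2ccc(Cl)cc2)ccc1OCCn1c(=O)ccn(C)c1=O` is not yet measured in this assay. It stands to compound 3 as compound 2 stands to compound 1: cyclopropyl in place of ethyl on a saturated chain carbon bound to an amine nitrogen. The place is the same in both pairs, so this is the same change made on the other core, and it occurs twice among the compounds shown.

Within the data shown here, for compound 4 the step is expected to be small, a 1.1-fold lower number from compound 3 to compound 4 (0.05 log units; within the scatter), resting on the one earlier example of the change, where compound 1 to compound 2 gave a 1.3-fold lower number from compound 1 to compound 2 (0.11 log units; within the scatter), a move that sits inside the scatter. With compound 3 already at 1 nm/s, compound 4 is therefore estimated at 0.9 nm/s, with a likely span from 0.4 nm/s to 2.5 nm/s.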

Compound 4, apparent permeability: 0.8 nm/s
Compound 4: the middle estimate sits 1.1-fold (0.05 log units) above what was measured, and the stated range covers the measured number.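

In this assay, cyclopropyl in place of ethyl on a saturated chain carbon bound to an amine nitrogen gives a 1.3-fold lower number from compound 3 to compound 4 (0.10 log units; within the scatter), so on the core of compound 3 the change leaves the number where it was, given the usual scatter of the measurement. Set beside the earlier pair, the change reads the same on both cores: the same change on two cores in this assay, a 1.3-fold lower number (0.11 log units; within the scatter) from compound 1 to compound 2 and a 1.3-fold lower number (0.10 log units; within the scatter) from compound 3 to compound 4, 1.0-fold (0.01 log units) apart, within the scatter of two such steps. This shows that in this series the near-absence of a step carried over from one core to the other, including to a core whose numbers lie far lower, but it rests on two pairs only, both steps lie within the scatter, and it shows neither a real effect of the change, however small, nor that the same would hold on any third core.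

Open, from the compounds shown here alone, is whether a different group at the same place, such as a butyl chain or a chain ending in a hydroxyl group, would produce a step beyond the scatter on either core. Also open is which part of the difference between the two cores goes with the gap in the numbers, since no pair shown differs in only one place there.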